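A few compounds are considered here, and "the series" means these few. Any claim that something is new, unique, unknown or untested is made for them only; others in the source may bear on it.

Compound 1 `Cc1nn(C)c(C)c1CN1C[C@H](CCCB(O)O)[C@](N)(C(=O)O)C1`: 340 nM
Compound 2 `C[C@@H](N)CN1C[C@H](CCCB(O)O)[C@](N)(C(=O)O)C1`: 16 nM
Compound 3 `C[C@H](N)CN1C[C@H](CCCB(O)O)[C@](N)(C(=O)O)C1`: 7.7 nM

In an assay for inhibition of arginase-1 (Homo sapiens), read by colorimetric assay, with a stated time of 60 min, in the presence of a further agent that is not named here (a lower number here means a stronger inhibitor, a higher number a weaker inhibitor), compound 3 gives the lowest number of the three. It is ahead of compound 2 by a 2.1-fold lower number from compound 2 to compound 3 (0.32 log units; beyond the scatter), a pair that differ only in configuration as drawn (the fact that compounds 2 and 3 differ only in the configuration as drawn), and far ahead of compound 1 by a 44-fold lower number from compound 1 to compound 3 (1.64 log units; beyond the scatter). Compound 4 `N[C@@]1(C(=O)O)CN(C[C@H]2COCCN2)C[C@@H]1CCCB(O)O` changes the same position once more: a group of 6 heavy atoms (4 carbon, 1 nitrogen, 1 oxygen; one six-membered non-aromatic ring with 2 hetero atoms) in place of a group of 3 heavy atoms (2 carbon, 1 nitrogen; no ring), on a saturated chain carbon bound to an amine nitrogen in a ring. For the measured compounds named here, the steps that bear on this place are a 21-fold lower number from compound 1 to compound 2 (1.33 log units; beyond the scatter) and a 44-fold lower number from compound 1 to compound 3 (1.64 log units; beyond the scatter), both large, showing that a small amine-containing chain here gives a much lower number than a methyl-bearing aromatic ring. The incoming group keeps a hydrogen-bond donor but brings a ring, so a modest rise in the number is expected, a 2.6-fold higher number from compound 3 to compound 4 (0.41 log units; beyond the scatter). Compound 4 is therefore estimated at 20 nM, likely between 6 nM and 70 nM.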

Compound 4, half-maximal inhibitory concentration: 19 nM
Estimate against measurement, compound 4: 1.1-fold (0.02 log units) above; measured number inside the range.
By their numbers in this assay, from the lowest: compound 3; then compounds 2 and 4 (each within the scatter of the next); then compound 1.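

A ring at this position does not by itself bring a high number: replacing the 1,3,5-trimethyl-1H-pyrazol-4-yl ring with the six-membered non-aromatic ring gives an 18-fold lower number from compound 1 to compound 4 (1.25 log units; beyond the scatter). Against the open-chain 1-aminoethyl group, the ring costs little, with a 2.5-fold higher number from compound 3 to compound 4 (0.39 log units; beyond the scatter) and a 1.2-fold higher number from compound 2 to compound 4 (0.07 log units; within the scatter). Nothing shown here gives a cause for these steps.

Still open, on these data alone, is whether the ring oxygen matters, which a six-membered ring with carbon in its place would test. The opposite configuration at the ring's stereocentre is also untested here.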